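Sulfone series: aryl amine replacement toward compound 4

The compounds below may be only part of what the source reports. "The series", "measured", "known", "first", "only" and "open" are said of these compounds alone.

Measured in a functional assay on DU-145 cells (Homo sapiens) for inhibition, read by trypan blue exclusion, with a stated time of 72 h; on this read-out lower numbers stand for stronger inhibition and higher numbers for weaker inhibition:
compound 1 `Cn1ccc2cc(Nc3ncc4cc(S(=O)(=O)c5ccc(F)cc5F)c(=O)n(C)c4n3)ccc21` gives 750 nM
compound 2 `COC(=O)Cn1ccc2cc(Nc3ncc4cc(S(=O)(=O)c5ccc(F)cc5F)c(=O)n(C)c4n3)ccc21` gives 5000 nM
compound 3 `Cc1ccc(S(=O)(=O)c2cc3cnc(Nc4cnc5c(c4)CC(=O)N5)nc3n(C)c2=O)cc1` gives 15000 nM

Compound 1 stands at the lowest number of the three. For the measured compounds named here, the one single-point step known is a 6.7-fold higher number from compound 1 to compound 2 (0.82 log units; beyond the scatter); compound 3 differs from compound 1 in more than one place and simply shows a higher number.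

Compound 4 `Cn1c(=O)c(S(=O)(=O)c2ccc(F)cc2F)cc2cnc(Nc3ccncn3)nc21` differs from compound 1 by pyrimidin-4-yl in place of 1-methyl-1H-indol-5-yl on a nitrogen on an aromatic ring. Going by the values given here, no measured step changes this amine partner, and the step from compound 1 to compound 2 concerns a group that leaves here, so it does not carry over. The change is therefore uncharted, and a weaker number is expected, a 5.3-fold higher number from compound 1 to compound 4 (0.73 log units; beyond the scatter). For compound 4 the estimate is 4000 nM, between 1000 nM and 20000 nM.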

Compound 4, half-maximal inhibitory concentration: 50000 nM
The estimate for compound 4 lay 13-fold (1.10 log units) below the measured number; the whole stated range lies below it.
By their numbers in this assay, from the lowest: compound 1; then compound 2; then compound 3; then compound 4.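

Exchanging the amine partner on the shared core matters far more than the earlier change on the chain: pyrimidin-4-yl in place of 1-methyl-1H-indol-5-yl gives a 67-fold higher number from compound 1 to compound 4 (1.82 log units; beyond the scatter) and exceeds the methoxycarbonyl step, a 6.7-fold higher number from compound 1 to compound 2 (0.82 log units; beyond the scatter) in the same assay. This single change removes the five-membered aromatic ring and brings a second ring nitrogen, and the two effects cannot be separated here. No available evidence accounts for the loss.

From the compounds shown here alone, it remains open whether phenyl or pyridin-3-yl on this nitrogen would restore the number of compound 1. Going by these compounds, the effect of a carboxylic acid in place of the methoxycarbonyl group also remains open.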